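The source may hold more compounds than are shown below. What is called first, only, known or untested is meant among the compounds shown, and "the series" means these compounds.

Measured so far:

- compound 1 `Cn1c(COc2cccc(C(=O)O)c2)nc2ccc(Oc3ccc(Cl)c(F)c3)nc21` — 2.2
- compound 2 `Cc1ccc(Oc2ccc3nc(COc4cccc(C(=O)O)c4)n(C)c3n2)c(C)c1` — 2.3

Two compounds share one core and differ only in the aryl group on the ether oxygen. In a physicochemical assay for lipophilicity, read by LC-MS, in phosphate buffer, measured as octanol-water partition, with a stated time of 30 min, at pH 7.4, tested at 200 mM (on this read-out higher numbers stand for higher lipophilicity and lower numbers for lower lipophilicity), compound 1 gives 2.2, the lower of the two numbers; compound 2 gives 2.3, and the step of a number 0.10 log units higher from compound 1 to compound 2 (within the scatter) stays within the scatter. On these numbers compound 1 and compound 2 cannot be told apart.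

Compound 3 `Cc1cc(C)cc(Oc2ccc3nc(COc4cccc(C(=O)O)c4)n(C)c3n2)c1` is not yet measured. Its change from compound 1 is 3,5-dimethylphenyl in place of 4-chloro-3-fluorophenyl on an oxygen on an aromatic ring. Going by the values given here, the only step that bears on it is the one from compound 1 to compound 2, which also exchanges 4-chloro-3-fluorophenyl for a dimethylphenyl group and was read as a number 0.10 log units higher from compound 1 to compound 2 (within the scatter). Compound 3 carries the same two methyl groups in another arrangement, so a step of about the same size is expected, that is a number 0.10 log units higher from compound 1 to compound 3 (within the scatter), with no change beyond the scatter. The expected value for compound 3 in this assay is 2.3, with a range from 2 to 2.6.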

Compound 3, distribution coefficient: 2.3
Estimate against measurement, compound 3: no gap at the digits printed, and the stated range covers the measured number.
By their numbers in this assay, from the lowest: compounds 1, 2 and 3 (each within the scatter of the next).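

In this assay, the step between the two dimethylphenyl isomers is (no change at the digits printed from compound 2 to compound 3 (within the scatter)), so on this read-out the two arrangements of the methyl groups on an oxygen on an aromatic ring cannot be told apart. The exchange of 4-chloro-3-fluorophenyl for 3,5-dimethylphenyl gives (a number 0.10 log units higher from compound 1 to compound 3 (within the scatter)), which means that a second dimethylphenyl group, and not only the 2,4-dimethylphenyl of compound 2, cannot be distinguished from the halogenated ring. Across these three compounds, with 8 heavy atoms in each aryl group, the position has not yet produced a step beyond the scatter, and nothing available offers an explanation for this.

As far as these compounds go, whether an amine, a hydroxyl group or a longer chain at this position would give a step beyond the scatter stays open. All three compounds also keep the carboxylic acid and the shared core, so these numbers say nothing about a tetrazole or an amide in place of that acid, or about any change to the core.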